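Removing the ethyl from the ether of compound 1

The source may report more compounds than this note shows. Statements on the series, on what has been measured and on what is new or still open speak of the compounds shown alone.

Three related compounds have been measured in an assay on liver for binding affinity to Alpha-1A adrenergic receptor (Homo sapiens), using microsomes; on this read-out higher numbers stand for weaker inhibition and lower numbers for stronger inhibition. Compound 1, with the structure `CCOc1ccccc1N1CCN(CCCNC(=O)N2C(=O)NC(C)=C(C(=O)OC)C2c2ccc(F)c(F)c2)CC1`, gives 0.1 nM in this assay, the lowest of the three numbers and therefore the strongest binding. Compound 2, with the structure `CC(=O)C1=C(C)NC(=O)N(C(=O)NCCCN2CCN(c3ccccc3C(N)=O)CC2)C1c1ccc(F)c(F)c1`, gives 0.7 nM, and compound 3, with the structure `CCC1=C(C(N)=O)C(c2ccc(F)cc2F)N(C(=O)NCCCN2CCN(c3ccccc3C(N)=O)CC2)C(=O)N1`, gives 1.3 nM; both gaps to compound 1 lie beyond the usual scatter of repeated measurements, so compound 1 stands apart as the most potent of the set.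

The unmeasured compound 4 has the structure `COC(=O)C1=C(C)NC(=O)N(C(=O)NCCCN2CCN(c3ccccc3O)CC2)C1c1ccc(F)c(F)c1`. It differs from compound 1 in one place: hydrogen in place of ethyl on an oxygen on an aromatic ring. The shared core and the rest of the molecule stay unchanged, so only the ethyl group disappears from the oxygen on the aromatic ring.

Going by the values given here, no pair of measured compounds shows this exact change, so the size of the step has to be guessed. Among the compounds with values here, compounds 2 and 3 carry a different group on that ring and bind somewhat less tightly than compound 1, which hints that the ethoxy group of compound 1 is favourable, yet no single step isolates its contribution. The expected outcome for compound 4 is a modest loss of affinity, a step from compound 1 to compound 4 of a 5.0-fold higher number from compound 1 to compound 4 (0.70 log units; beyond the scatter), likely a little beyond the scatter. Compound 4 is therefore estimated to give 0.5 nM in this assay, within a range of 0.1 nM to 3 nM.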

Compound 4, inhibition constant: 0.6 nM
The estimate for compound 4 lay 1.2-fold (0.08 log units) below the measured number; low and high end bracket the measured number.
By their numbers in this assay, from the lowest: compound 1; then compounds 4, 2 and 3 (each within the scatter of the next, the first and the last beyond it).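

Going by these compounds alone, the step of a 6.0-fold higher number from compound 1 to compound 4 (0.78 log units; beyond the scatter) in this assay is the first change in this set that can be read on its own, since compounds 2 and 3 differ from compound 1 in several places at once. It shows that going from ethoxy to hydroxy on this aromatic ring costs binding affinity by more than the usual scatter, so the ethyl group on the oxygen does make a measurable difference. The loss is limited, however: without the ethyl group, compound 4 still gives 0.6 nM, so this read-out stays low even with only a hydrogen on that oxygen, and nothing measured here explains the size of the step.

This single step cannot show whether binding depends on the length of the chain on the oxygen, which a methoxy group or a longer propoxy group at this place would begin to test. Going by these compounds, an amine in place of the hydroxy would also show whether the oxygen itself matters, and that question stays open for now.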